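A Cytotoxicity Gap and One Added Oxygen

The source may report more compounds than this note shows. Statements on the series, on what has been measured and on what is new or still open speak of the compounds shown alone.

Two compounds anchor this account in a functional assay on HeLa cells (Homo sapiens) for cytotoxicity, read by MTT assay; a lower number here means a stronger inhibitor, a higher number a weaker inhibitor. For the measured compounds named here, compound 1 (`CC1(C)O[C@H]([C@H]2COC(C)(C)O2)[C@@H](C2CC(=O)SS2)O1`) gives 35900 nM, which is the only number available. Compound 2 (`Cc1cn([C@H]2C[C@H](O[Si](C)(C)C(C)(C)C)[C@@H](C3CC(=O)SS3)O2)c(=O)[nH]c1=O`) stands without a number, its entry reading "not determined" (no result reported), so its place relative to compound 1 cannot be told.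

Compound 3 (`Cc1cn([C@H]2C[C@H](O[Si](C)(C)C(C)(C)C)[C@@H](C3CC(=O)S[S+]3[O-])O2)c(=O)[nH]c1=O`) is the next compound to be considered, and it departs from compound 2 in one place. The difference is a group of 7 heavy atoms (3 carbon, 2 oxygen, 2 sulfur; one five-membered non-aromatic ring with 2 hetero atoms) in place of a group of 6 heavy atoms (3 carbon, 1 oxygen, 2 sulfur; one five-membered non-aromatic ring with 2 hetero atoms), on a saturated ring carbon: a group of 7 heavy atoms replaces a group of 6 heavy atoms, on a saturated ring carbon of a five-membered non-aromatic ring with 1 oxygen, next to the ring oxygen.

Going by the values given here, no measured step shows what this change does in this assay, and compound 2 offers no baseline. The expectation therefore rests on compound 1 at 35900 nM, and it is tentative: a moderate step toward stronger inhibition, though a result within the scatter of that figure would not be surprising. Compound 3 is expected at an estimated 15000 nM, within a range of 4000 nM to 60000 nM.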

Compound 3, half-maximal inhibitory concentration: 43100 nM
Estimate against measurement, compound 3: 2.9-fold (0.46 log units) below; the measured number falls inside the stated range.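

In this assay, for the compounds shown here, compound 3 gives 43100 nM while compound 2 has no number there, so no step between compound 2 and compound 3 can be read. From the compounds shown here alone, what the added oxygen does to cytotoxicity stays open, as does where compound 2 stands beside compound 1 and compound 3. No supporting evidence bears on this result.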